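Working notes: cyclohexyl to 4-chlorophenyl on the shared core

This account rests on a few compounds, and the source may have more. Where it says the series, first, only, none or still open, it means among the compounds named here.

- compound 1 `COc1ccc(C(c2c[nH]c3ccc(Br)cc23)c2c[nH]c3ccc(Br)cc23)cc1` at 5500 nM
- compound 2 `Brc1ccc2[nH]cc(C(c3c[nH]c4ccc(Br)cc34)C3CCCCC3)c2c1` at 3200 nM

In a functional assay on HeLa cells (Homo sapiens) for inhibition, read by MTT assay, with a stated time of 48 h (on this read-out lower numbers stand for stronger inhibition and higher numbers for weaker inhibition), compound 2 gives 3200 nM and compound 1 gives 5500 nM and the two lie within the scatter of each other. Compound 3 `Clc1ccc(C(c2c[nH]c3ccc(Br)cc23)c2c[nH]c3ccc(Br)cc23)cc1` has not been measured. The change from compound 2 is 4-chlorophenyl in place of cyclohexyl on a saturated chain carbon bound to two aromatic carbons and it puts 4-chlorophenyl in place of cyclohexyl on a saturated chain carbon bound to two aromatic carbons. Going by the values given here, one measured step bears on this, a 1.7-fold lower number from compound 1 to compound 2 (0.24 log units; within the scatter) for cyclohexyl in place of 4-methoxyphenyl at that same carbon. Among the compounds with values here, no compound with 4-chlorophenyl has a value yet, so this single step is the only guide. No change beyond the scatter is therefore expected in this assay here. The expected result is a 1.4-fold higher number from compound 2 to compound 3 (0.15 log units; within the scatter) as a working figure. Compound 3 is expected at 4500 nM with an estimated range from 1800 nM to 11000 nM for now.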

Compound 3, half-maximal inhibitory concentration: 4800 nM
For compound 3 the middle estimate is 1.1-fold (0.03 log units) below the measured one; the measured number falls inside the stated range.
By their numbers in this assay, from the lowest: compounds 2, 3 and 1 (each within the scatter of the next).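

In this assay, the 4-chlorophenyl in place of cyclohexyl on a saturated chain carbon bound to two aromatic carbons gives a 1.5-fold higher number from compound 2 to compound 3 (0.18 log units; within the scatter), so across these compounds, a six-membered aromatic ring and a six-membered non-aromatic ring at this carbon are not told apart. The series now also has a change on the aromatic ring itself: chloro in place of methoxy on an aromatic carbon gives a 1.1-fold lower number from compound 1 to compound 3 (0.06 log units; within the scatter), and this step also stays within the scatter. Nothing available explains how close these numbers lie.

The compounds shown all carry a six-membered ring at this carbon, so they do not show whether any group there can move the number beyond the scatter. An amine, a carboxylic acid or a longer chain at this carbon would test that.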